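Amine nitrogen substituent variation in the series

The source may hold more compounds than are shown below. What is called first, only, known or untested is meant among the compounds shown, and "the series" means these compounds.

Compound 1 `CC1(OC(=O)N2CCC(O[C@H]3CC[C@H](Oc4cnc(S(C)(=O)=O)cn4)CC3)CC2)CC1` gives 25.9 nM in a functional assay on isolated protein for agonist activity at Glucose-dependent insulinotropic receptor (Homo sapiens), read by HTRF and cAMP accumulation; a lower number here means that less compound is needed, a higher number that more compound is needed for the effect. Going by the values given here, compound 2 `CS(=O)(=O)c1cnc(O[C@H]2CC[C@H](OC3CCN(CC4(C(F)(F)F)CCC4)CC3)CC2)cn1` gives 54.8 nM in this assay, the highest of the two numbers so far; the step of a 2.1-fold higher number from compound 1 to compound 2 (0.33 log units; beyond the scatter) accompanies the exchange of ((1-methylcyclopropyl)oxy)carbonyl for (1-(trifluoromethyl)cyclobutyl)methyl on the amine nitrogen in the ring. Compound 3 `CC(F)Cc1nc(CN2CCC(O[C@H]3CC[C@H](Oc4cnc(S(C)(=O)=O)cn4)CC3)CC2)no1` is not yet measured. Its change from compound 2 is 5-(2-fluoropropyl)-1,2,4-oxadiazol-3-yl in place of 1-(trifluoromethyl)cyclobutyl on a saturated chain carbon bound to an amine nitrogen in a ring: a four-membered carbon-only ring leaves and a five-membered aromatic ring with 3 hetero atoms and 3 hydrogen-bond acceptors enters on the saturated chain carbon bound to the amine nitrogen. Among the compounds with values here, no measured step covers this exchange; the single recorded step, from compound 1 to compound 2, alters the same position but neither of its groups resembles the entering one, so it bears only loosely. A step within the scatter, or a modest one in either direction, is therefore expected in this assay, a 1.4-fold lower number from compound 2 to compound 3 (0.14 log units; within the scatter). Compound 3 is estimated at 40 nM, with a range of 12 nM to 130 nM.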

Compound 3, half-maximal effective concentration: 30.3 nM
For compound 3 the middle estimate is 1.3-fold (0.12 log units) above the measured one; measured number inside the range.
By their numbers in this assay, from the lowest: compounds 1, 3 and 2 (each within the scatter of the next, the first and the last beyond it).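

On the amine nitrogen in the ring, the (5-(2-fluoropropyl)-1,2,4-oxadiazol-3-yl)methyl group stands within the scatter of both earlier substituents in this assay, with a 1.8-fold lower number from compound 2 to compound 3 (0.26 log units; within the scatter) and a 1.2-fold higher number from compound 1 to compound 3 (0.07 log units; within the scatter). A five-membered aromatic ring with 3 hetero atoms and 3 hydrogen-bond acceptors is therefore tolerated in place of 1-(trifluoromethyl)cyclobutyl on the saturated chain carbon bound to that nitrogen, and compound 3 cannot be placed on either side of the gap between compound 1 and compound 2. No measurement at hand accounts for these numbers.

Still open is what the 2-fluoropropyl part contributes, as the compounds shown do not separate it from the ring that carries it. An ethyl chain, a primary amine or a carboxylic acid at that place on the ring would address this.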